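This account rests on a few compounds, and the source may have more. Where it says the series, first, only, none or still open, it means among the compounds named here.

Compound 1, `C[n+]1ccn(CCC#N)c1/C=N/O`, gives -3.3 in a physicochemical assay for lipophilicity; a lower number here means a more polar compound, a higher number a more lipophilic compound.
Compound 2, `C[n+]1ccn(COCC(C)(C)CBr)c1/C=N/O`, gives -0.81 in this assay.

Of these two numbers, compound 1 stands lowest; its nearest neighbour is compound 2, which sits higher by a margin beyond the usual scatter of this assay. Among the compounds with values here, no measured pair differs in only one place, so no single structural step can be read off directly.

Compound 3, `C[n+]1ccn(CCS(C)(=O)=O)c1/C=N/O`, has not yet been measured. It differs from compound 1 by one change: methylsulfonyl in place of cyano on a saturated chain carbon, two bonds along the chain from an aromatic nitrogen. Within the data shown here, no measured pair here shows what this exchange does to this assay, so the expectation rests on the starting point alone. Compound 3 is expected to come out somewhat lower than compound 1, with a step of a number 0.50 log units lower from compound 1 to compound 3 (beyond the scatter) that may or may not exceed the scatter. For compound 3 the estimated value is -3.8, within a range from -4.6 to -3.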

Compound 3, distribution coefficient: -3.5
The estimate for compound 3 lay 0.30 log units below the measured number; measured number inside the range.
By their numbers in this assay, from the lowest: compounds 3 and 1 (each within the scatter of the next); then compound 2.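

In this assay, the exchange of cyano for methylsulfonyl on a saturated chain carbon, two bonds along the chain from an aromatic nitrogen, gives a number 0.20 log units lower from compound 1 to compound 3 (within the scatter) on the shared core. At this position, then, a group of 4 heavy atoms with 2 hydrogen-bond acceptors and a group of 2 heavy atoms with 1 hydrogen-bond acceptor cannot be told apart by this measurement. No measurement here explains why these two groups read alike.

On these data alone, it remains open whether other groups at this place, such as an amine, a carboxylic acid or a longer chain, would also stay within the scatter of compound 1. As far as these compounds go, it is also open whether the same exchange would give a similar step on a different chain.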